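Fibroblast toxicity notes: fluoro to tert-butyl step

The source may report more compounds than this note shows. Statements on the series, on what has been measured and on what is new or still open speak of the compounds shown alone.

Measured so far:
compound 1 `COC(=O)c1ccc(NCc2cncn2Cc2cccc(F)c2)cc1-c1ccccc1`, in a toxicity assay on NIH3T3 cells (Mus musculus) for cytotoxicity, read by resazurin assay (a higher number here means that more compound is needed for the effect, a lower number that less compound is needed), compound 1 gives > 1000 nM, a limit of the assay and not a number.
compound 2 `c1ccc(-c2ccc(Cn3cncc3CNc3ccc(N4CCCC4)c(-c4ccccc4)c3)cc2)cc1`, in this assay compound 2 gives > 1000 nM, again a limit.
compound 3 `Cc1ccc(Cn2cncc2CNc2cccc(-c3ccccc3)c2)cc1`, in this assay compound 3 gives 10000 nM.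

Compound 1 therefore stands only at a limit; nothing in the numbers shown ranks it against compound 2, since both rest at the limit of > 1000 nM in this assay, at which 2 of the 3 values shown sit. Only compound 3 gives a number, and it lies weak.

Compound 4 `COC(=O)c1ccc(NCc2cncn2Cc2cccc(C(C)(C)C)c2)cc1-c1ccccc1` is not yet measured. Its difference from compound 1 is tert-butyl in place of fluoro on an aromatic carbon. Among the compounds with values here, with no measured step in hand, the expectation is no step beyond the usual scatter, the estimated change being a step that the limit leaves unreadable from compound 1 to compound 4. Compound 4 is expected at 8000 nM, with a range from 2000 nM to 30000 nM, and a limit rather than a number is thought likely.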

Compound 4, half-maximal effective concentration: > 1000 nM
Compound 4: a limit, no number; the forecaster's own chance of this, stated with the estimate: 60%; the middle value is on the limit's open side.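

Within the data shown here, compound 1 and compound 4 both stand only at a limit in this assay, and no step between them can be read: the limit of > 1000 nM in this assay, at which 3 of the 4 values shown sit. The compounds shown leave open whether tert-butyl in place of fluoro changes the half-maximal effective concentration at all.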